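A few compounds are considered here, and "the series" means these few. Any claim that something is new, unique, unknown or untested is made for them only; others in the source may bear on it.

Measured compounds in this study:
compound 1, `COc1nn2cc(-c3cc4ccc(OCc5ccccc5)cc4o3)nc2s1`, > 30000 nM
compound 2, `COc1nn2cc(-c3cc4c(OC)ccc(OC)c4o3)nc2s1`, 10000 nM
compound 3, `COc1nn2cc(-c3cc4ccccc4o3)nc2s1`, 15000 nM

In an assay on a cell-free system (plasma) for antagonist activity at proteinase-activated receptor 4 (Homo sapiens), with a stated time of 5 min, in the presence of a further agent that is not named here (on this read-out higher numbers stand for weaker inhibition and lower numbers for stronger inhibition), compound 3 stands at the higher of the two numbers given, with compound 2 nearest to it; the two lie within the usual scatter of each other. The value of compound 1 is a limit of the assay, not a number. One of the three values sits at that limit, (the limit of > 30000 nM in this assay, at which 1 of the 3 values shown sits). Compound 4, `COc1nn2cc(-c3cc4c(OC)cccc4o3)nc2s1`, differs from compound 3 by methoxy in place of hydrogen on an aromatic carbon. Among the measured compounds shown here, the single measured step, an at least 2.0-fold lower number from compound 1 to compound 3 (0.30 log units; that floor lies within the scatter), concerns a different group and bears only loosely on this change; the values of compound 2 and compound 3 show no separation beyond the scatter for methoxy on the fused ring. Compound 4 is therefore expected to show no step beyond the scatter, a 1.3-fold lower number from compound 3 to compound 4 (0.10 log units; within the scatter). For compound 4 the estimate is 12000 nM, between 5000 nM and 30000 nM.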

Compound 4, half-maximal inhibitory concentration: 1300 nM
Compound 4: the middle estimate sits 9.2-fold (0.97 log units) above what was measured; measured number below the stated range.
By their numbers in this assay, from the lowest: compound 4; then compounds 2 and 3 (each within the scatter of the next). At a limit, above all of these: compound 1.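

In this assay, a single methoxy on the six-membered aromatic ring brings a 12-fold lower number from compound 3 to compound 4 (1.06 log units; beyond the scatter), a large step that the pair of compound 2 and compound 3 gave no sign of. Compound 2 carries this methoxy and a further one, and removing that further methoxy brings a 7.7-fold lower number from compound 2 to compound 4 (0.89 log units; beyond the scatter), a modest step beyond the scatter. The gain from this methoxy thus appears here only where the further methoxy is absent.

The compounds shown leave open whether a hydroxyl, an ethoxy or an amine on this carbon would match methoxy. No measurement given here bears on the cause of these steps.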